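This account rests on a few compounds, and the source may have more. Where it says the series, first, only, none or still open, it means among the compounds named here.

Measured in an ADME assay on a cell-free system (plasma, Homo sapiens) for metabolic stability; a higher number here means that the compound lasts longer, a lower number that the compound disappears faster:
Compound 1 `CC(=O)N1C(=O)C(C)(C)[C@@H]2[C@@H]1CCN2C(=O)OCc1ccccc1`: 6.5 h
Compound 2 `CNC(=O)N1C(=O)[C@@H](C)[C@@H]2[C@@H]1CCN2C(=O)OCc1ccccc1`: > 24 h

The reading for compound 2 is a limit of the assay and not a number: the limit of > 24 h in this assay, at which 1 of the 2 values shown sits. Compound 3 `C[C@@H]1C(=O)N(c2nccs2)[C@H]2CCN(C(=O)OCc3ccccc3)[C@H]12` differs from compound 2 by 1,3-thiazol-2-yl in place of methylcarbamoyl on an amide-type nitrogen in a ring, with 1,3-thiazol-2-yl in place of methylcarbamoyl on an amide-type nitrogen in a ring. For the measured compounds named here, no measured step shows what such a change does. Going by the values given here, the only numerical reading is compound 1 at 6.5 h, which also lacks methylcarbamoyl, so a fall beyond the scatter in this assay is expected, an at least 2.4-fold lower number from compound 2 to compound 3 (0.38 log units; beyond the scatter). The half-life of compound 3 is estimated at 10 h, within a range of 3 h to 24 h.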

Compound 3, half-life: 44 h
Estimate against measurement, compound 3: 4.4-fold (0.64 log units) below; measured number outside the range, above it.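

For the compounds shown here, no step from compound 2 to compound 3 can be read, because compound 2 carries a limit and not a number: the limit of > 24 h in this assay, at which 1 of the 3 values shown sits. The compounds shown leave open what 1,3-thiazol-2-yl in place of methylcarbamoyl does to the half-life.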